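Moving a Methyl from Pyrazole Carbon to Pyrazole Nitrogen

The source may hold more compounds than are shown below. What is called first, only, known or untested is meant among the compounds shown, and "the series" means these compounds.

The compounds measured so far, with their numbers in an assay on HeLa cells for inhibition of MAP kinase-interacting serine/threonine-protein kinase 1/2 (Homo sapiens), read by AlphaScreen, with a stated time of 2 h; a lower number here means a stronger inhibitor, a higher number a weaker inhibitor:
compound 1, `CC(C)Oc1cc(-c2cncc(-c3cnn(C4COC4)c3)c2)ccc1C(N)=O`, gives 200 nM;
compound 2, `CC(C)Oc1cc(-c2cncc(-c3cnn(C(C)C)c3)c2)ccc1C(N)=O`, gives 940 nM;
compound 3, `Cc1n[nH]c(C)c1-c1cncc(-c2ccc(C(N)=O)c(OC(C)C)c2)c1`, gives 160 nM.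

Compound 3 has the lowest number of the three, but its gap to compound 1 is within the scatter, so the two cannot be ranked against each other; only compound 2 clearly stands apart, as a 5.9-fold lower number from compound 2 to compound 3 (0.77 log units; beyond the scatter) shows.

Compound 4, `Cc1c(-c2cncc(-c3ccc(C(N)=O)c(OC(C)C)c3)c2)cnn1C`, differs from compound 3 in one place: 1,5-dimethyl-1H-pyrazol-4-yl in place of 3,5-dimethyl-1H-pyrazol-4-yl on an aromatic carbon. The same atoms are present, but a methyl has moved from a ring carbon to the ring nitrogen, so the hydrogen-bond donor of compound 3 is gone and a second acceptor appears.

Within the data shown here, no measured step is exactly this swap. The closest guides are a 4.7-fold higher number from compound 1 to compound 2 (0.67 log units; beyond the scatter), where a larger group on the ring nitrogen weakened binding, and a 5.9-fold lower number from compound 2 to compound 3 (0.77 log units; beyond the scatter), where the unsubstituted ring nitrogen with two carbon-bound methyls recovered it. Compound 1, with a ring-nitrogen substituent and no donor, still sits close to compound 3. A methyl is small, so compound 4 is expected to lose little, within or just beyond the scatter, an estimated step of a 2.2-fold higher number from compound 3 to compound 4 (0.34 log units; beyond the scatter). For compound 4 the expected value in this assay is 350 nM, with a likely range from 120 nM to 1000 nM.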

Compound 4, half-maximal inhibitory concentration: 2200 nM
Beside the measured number, compound 4's estimate is 6.3-fold (0.80 log units) below it, and the stated range ends below it.
By their numbers in this assay, from the lowest: compounds 3 and 1 (each within the scatter of the next); then compound 2; then compound 4.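

The step of a 14-fold higher number from compound 3 to compound 4 (1.14 log units; beyond the scatter) in this assay shows that this position responds to how the atoms of the pyrazole are arranged, not only to which atoms are present: the two groups have the same heavy atoms, yet the entering one has 0 hydrogen-bond donors where the leaving one has 1. Losing that donor cannot be the whole account, as an 11-fold higher number from compound 1 to compound 4 (1.04 log units; beyond the scatter) is also a large step even though compound 1 carries a substituent on the ring nitrogen and stays within the scatter of compound 3. A small group on the ring nitrogen is also no guarantee of a low number, as a 2.3-fold higher number from compound 2 to compound 4 (0.37 log units; beyond the scatter) shows, although compound 4 differs from compounds 1 and 2 in its ring-carbon methyl as well as in its nitrogen group.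

Nothing shown here explains the large cost of this rearrangement. As far as these compounds go, it also remains open whether the cost follows the methyl on the nitrogen or the methyl on the carbon, a question that 1-methyl-1H-pyrazol-4-yl, with no carbon-bound methyl, or the unsubstituted 1H-pyrazol-4-yl could help to separate.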